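A few compounds are considered here, and "the series" means these few. Any claim that something is new, unique, unknown or untested is made for them only; others in the source may bear on it.

Compound 1 `O=[N+]([O-])c1cc2c(OCCC3CCCCN3)c(-c3cccc(Cl)c3)c(O)nc2cc1Cl` gives 40 nM in a functional assay on cells (Pituitary gland cell) for antagonist activity at Gonadotropin-releasing hormone receptor (Rattus norvegicus); on this read-out higher numbers stand for weaker inhibition and lower numbers for stronger inhibition.
Compound 2 `O=[N+]([O-])c1cc2c(OCCC3CCCCN3)c(-c3ccccc3)c(O)nc2cc1Cl` gives 410 nM in this assay.
Compound 3 `COc1ccc(-c2c(O)nc3cc(Cl)c([N+](=O)[O-])cc3c2OCCC2CCCCN2)cc1OC` gives 600 nM in this assay.

Among these three, compound 3 has the highest number. Its nearest neighbour is compound 2, and the step of a 1.5-fold higher number from compound 2 to compound 3 (0.17 log units; within the scatter) stays within the scatter, so these two cannot be ordered. Compound 1 stands furthest away, with a 15-fold higher number from compound 1 to compound 3 (1.18 log units; beyond the scatter). The remaining measured step, a 10-fold higher number from compound 1 to compound 2 (1.01 log units; beyond the scatter), is also large.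

Compound 4 `O=[N+]([O-])c1cc2c(OCCC3CCCCN3)c(-c3ccc4ccccc4c3)c(O)nc2cc1Cl` differs from compound 3 in one place: naphthalen-2-yl in place of 3,4-dimethoxyphenyl on an aromatic carbon. Among the measured compounds shown here, none of the measured steps exchanges a single six-membered aryl group for a fused two-ring aryl, so no step bears directly on this change. What the three numbers do show is that the aryl group matters a great deal: compound 1 stands well apart, while compound 2 and compound 3 sit together at the weak end. Naphthalen-2-yl carries no hydrogen-bond acceptors, which sets it apart from the 3,4-dimethoxyphenyl of compound 3. The expectation is therefore that compound 4 moves toward a lower number than compound 3, by a step of a 4.0-fold lower number from compound 3 to compound 4 (0.60 log units; beyond the scatter) in this assay, though with wide uncertainty. The estimate for compound 4 in this assay is 150 nM, with a range from 30 nM to 700 nM.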

Compound 4, half-maximal inhibitory concentration: 53 nM
Compound 4: the middle estimate sits 2.8-fold (0.45 log units) above what was measured; the range from low to high includes it.
By their numbers in this assay, from the lowest: compounds 1 and 4 (each within the scatter of the next); then compounds 2 and 3 (each within the scatter of the next).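

Placing naphthalen-2-yl on this aromatic carbon gives an 11-fold lower number from compound 3 to compound 4 (1.05 log units; beyond the scatter) and a 7.7-fold lower number from compound 2 to compound 4 (0.89 log units; beyond the scatter), so 3-chlorophenyl is no longer the only aryl group here that stands clear of phenyl and 3,4-dimethoxyphenyl in this assay. Exchanging 3-chlorophenyl for naphthalen-2-yl gives a 1.3-fold higher number from compound 1 to compound 4 (0.12 log units; within the scatter), which leaves those two compounds unordered, and the gap between compound 3 and compound 4 arises with the same heavy-atom count on both sides, the groups differing instead in their atoms, their aromatic rings and their hydrogen-bond acceptors. Nothing available here accounts for the difference between these aryl groups.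

The compounds shown leave open whether naphthalen-1-yl or quinolin-3-yl would join naphthalen-2-yl and 3-chlorophenyl, which would show how much the attachment point and the all-carbon makeup of the fused rings count at this position. They also leave open how 3-methoxyphenyl, 4-chlorophenyl or 3,4-dichlorophenyl would compare, which would help separate the effect of each substituent from that of its place on the ring.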